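Urea to amide in a pyrazole series

This account rests on a few compounds, and the source may have more. Where it says the series, first, only, none or still open, it means among the compounds named here.

Measured compounds and read-outs in a functional assay on HCC 2998 cells (Homo sapiens) for inhibition, read by sulforhodamine B assay, with a stated time of 48 h, tested at 0.01 uM; a lower number here means a stronger effect, a higher number a weaker effect of the compound at the concentration tested:
compound 1, `COc1cc(Cl)cc(-c2nn(-c3cccc(NC(=O)Nc4ccc(Cl)c(C(F)(F)F)c4)c3)cc2-c2ccncc2)c1`, gives 95%
compound 2, `COc1cc(Cl)cc(-c2nn(-c3cccc(NC(=O)Nc4ccc(Cl)c(Cl)c4)c3)cc2-c2ccncc2)c1`, gives 93%
compound 3, `COc1cc(Cl)cc(-c2nn(-c3cccc(NC(=O)Nc4cccc(C(F)(F)F)c4)c3)cc2-c2ccncc2)c1`, gives 98%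

All three numbers sit close together. Compound 3 holds the highest of the three, with compound 1 nearest at a number 3 percentage points higher from compound 1 to compound 3 (within the scatter) and compound 2 furthest at a number 5 percentage points higher from compound 2 to compound 3 (within the scatter), both within the scatter, so no order among the three can be read. The step of a number 2 percentage points lower from compound 1 to compound 2 (within the scatter) is likewise within the scatter.

Compound 4, `COc1cc(Cl)cc(-c2nn(-c3cccc(NC(=O)c4cccc(C(F)(F)F)c4)c3)cc2-c2ccncc2)c1`, is not yet measured. It differs from compound 3 at the carbonyl carbon: 3-(trifluoromethyl)phenyl in place of (3-(trifluoromethyl)phenyl)amino on a carbonyl carbon. The urea of compound 3 becomes an amide, the amide-type nitrogen on the other side of the carbonyl staying in place. Within the data shown here, none of the measured steps touches this part of the molecule; all three concern the substituents on the outer aromatic ring, and none moved the read-out beyond the scatter. No basis therefore exists for expecting a change beyond the scatter in this assay. The value of compound 4 is estimated at 97%, between 85% and 104%, an expected step of a number 1 percentage points lower from compound 3 to compound 4 (within the scatter).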

Compound 4, a percentage reported as activity, at one concentration (the size of the read-out at that concentration, not a potency): 108%
Compound 4: middle estimate off by 11 percentage points, on the low side; the measured number lies above the stated range.
By their numbers in this assay, from the lowest: compounds 2, 1, 3 and 4 (each within the scatter of the next, the first and the last beyond it).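

Among these compounds, at the carbonyl carbon, the nitrogen of the urea and its hydrogen-bond donor leave with the change to 3-(trifluoromethyl)phenyl, the first change away from the substituents on the outer aromatic ring; in this assay this gives a number 10 percentage points higher from compound 3 to compound 4 (within the scatter). Among the compounds shown here, the steps that also alter the ring substituents, a number 15 percentage points higher from compound 2 to compound 4 (beyond the scatter) and a number 13 percentage points higher from compound 1 to compound 4 (beyond the scatter), do pass the scatter, towards a weaker effect at the concentration tested, which no step among the three ureas did. Nothing at hand bears on why the number moves at this position.

Open, from the compounds shown here alone, is whether an amide carrying the 4-chloro-3-(trifluoromethyl)phenyl or 3,4-dichlorophenyl ring would separate the effect of the linker from that of the ring. Also open, going by these compounds, is how a carbamate or a methylene in place of the urea nitrogen would read here.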